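The compounds below may be only part of what the source reports. "The series", "measured", "known", "first", "only" and "open" are said of these compounds alone.

Three compounds have been measured:
compound 1 `COc1cc(-c2cc(/C=C/C(=O)c3ccc(N)cc3)[nH]n2)cc(OC)c1OC` gives 1400 nM
compound 2 `COc1ccc(-c2cc(/C=C/C(=O)c3ccc(N)cc3)[nH]n2)cc1OC` gives 2680 nM
compound 3 `COc1cc(C(=O)/C=C/c2cc(-c3cc(OC)c(OC)c(OC)c3)n[nH]2)cc(OC)c1OC` gives 1450 nM

All of these values come from a functional assay on OVCAR-4 cells (Homo sapiens) for inhibition, read by sulforhodamine B assay, with a stated time of 48 h; on this read-out lower numbers stand for stronger inhibition of growth and higher numbers for weaker inhibition of growth. Compound 1 and compound 2 share one core and differ in a single place: hydrogen in place of methoxy on an aromatic carbon. That change produced a 1.9-fold higher number from compound 1 to compound 2 (0.28 log units; within the scatter), so the two compounds cannot be told apart with confidence in this assay. Compound 3 is built on a different core; the difference between the two cores is not broken down here. Its value lies within the scatter of that of compound 1, and also within the scatter of that of compound 2, so no ordering among the three can be claimed.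

Compound 4 `COc1ccc(-c2cc(/C=C/C(=O)c3cc(OC)c(OC)c(OC)c3)[nH]n2)cc1OC` has not yet been measured. It arises from compound 3 by the change (hydrogen in place of methoxy on an aromatic carbon), and the surroundings of that place read the same, word for word, as in the change from compound 1 to compound 2. Among the compounds with values here, the change is therefore the same one, and the only guide to its effect is the step measured earlier, which stayed within the scatter. On that basis the expected step is a 1.7-fold higher number from compound 3 to compound 4 (0.24 log units; within the scatter), resting on a 1.9-fold higher number from compound 1 to compound 2 (0.28 log units; within the scatter). Compound 4 is therefore expected to give about 2500 nM in this assay, most likely falling between 1200 nM and 5500 nM.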

Compound 4, concentration for 50% growth inhibition: 1620 nM
Compound 4: the middle estimate sits 1.5-fold (0.19 log units) above what was measured; the range from low to high includes it.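

In this assay, putting hydrogen in place of methoxy on the second core gave a 1.1-fold higher number from compound 3 to compound 4 (0.05 log units; within the scatter). Set beside the earlier case, the change behaves alike on both cores as far as this read-out can tell: the same change on two cores in this assay, a 1.9-fold higher number (0.28 log units; within the scatter) from compound 1 to compound 2 and a 1.1-fold higher number (0.05 log units; within the scatter) from compound 3 to compound 4, 1.7-fold (0.23 log units) apart, within the scatter of two such steps. Within the data shown here, both steps are small enough to be lost in the ordinary spread of repeated measurements, so the result shows only that this change left no readable mark on either core; it does not show that the true effect is zero or that it is exactly the same on both cores, and two cores are too few to support a general rule for the series.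

The compounds shown leave open what a different group at this place on the aromatic ring would do, such as a hydroxyl, a fluorine or a carboxylic acid in place of the methoxy, and whether any of these would move the number beyond the scatter on either core. They also leave open whether the same small step would appear in other cell lines or after a different exposure time.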